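Replacing the Amino Group of Compound 1 with Methoxy

The compounds below may be only part of what the source reports. "The series", "measured", "known", "first", "only" and "open" are said of these compounds alone.

compound 1 `COc1cc(-c2cc(/C=C/C(=O)c3ccc(N)cc3)[nH]n2)cc(OC)c1OC`: 88%
compound 2 `COc1cc(-c2cc(/C=C/C(=O)c3ccc(Cl)c(Cl)c3)[nH]n2)cc(OC)c1OC`: 105%

In a functional assay on Hs-578T cells (Homo sapiens) for cytotoxicity, read by sulforhodamine B assay, with a stated time of 48 h, tested at 0.1 uM (on this read-out lower numbers stand for a stronger effect and higher numbers for a weaker effect at the one concentration tested), compound 1 gives 88%, the lowest of the two numbers shown, and compound 2 gives 105%, the step between them being a number 17 percentage points higher from compound 1 to compound 2 (beyond the scatter). Compound 3 `COc1ccc(C(=O)/C=C/c2cc(-c3cc(OC)c(OC)c(OC)c3)n[nH]2)cc1` differs from compound 1 in one place: methoxy in place of amino on an aromatic carbon. Within the data shown here, no measured step reproduces this exact change; the one step available, a number 17 percentage points higher from compound 1 to compound 2 (beyond the scatter), also removes the 4-aminophenyl and raised the number modestly. On that basis a small rise is expected, a number 9 percentage points higher from compound 1 to compound 3 (within the scatter). Compound 3 is estimated at 97%, within 82% to 112%.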

Compound 3, a percentage reported as activity, at one concentration (the size of the read-out at that concentration, not a potency): 100%
For compound 3 the middle estimate is 3 percentage points below the measured one, and the stated range covers the measured number.
By their numbers in this assay, from the lowest: compound 1; then compounds 3 and 2 (each within the scatter of the next).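

With the rest of compound 1 kept, methoxy in place of amino alone gives a number 12 percentage points higher from compound 1 to compound 3 (beyond the scatter) in this assay, so the loss of the amino group is enough for a modest rise, without any chlorine. The 4-methoxyphenyl and 3,4-dichlorophenyl groups cannot be told apart, with a number 5 percentage points lower from compound 2 to compound 3 (within the scatter) and only compound 1 standing apart from the other two. The data shown offer no explanation for this. As far as these compounds go, whether a dimethylamino or hydroxyl group at this position would keep the lower number of compound 1 remains open.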